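The compounds below may be only part of what the source reports. "The series", "measured", "known", "first", "only" and "open" are said of these compounds alone.

Working notes on the series.

Of the compounds shown here, two of this set have numbers so far. Compound 1 `C=C1C(=O)O[C@@H]2[C@@H]1C[C@H](OC(C)=O)[C@](C)(O)CC/C=C(\C)CC/C=C(\C)[C@@H]2OC(C)=O` gives 12.1 ug/mL in a functional assay on A549 cells (Homo sapiens) for cytotoxicity, read by colorimetric assay and MTT assay (a higher number here means a weaker inhibitor, a lower number a stronger inhibitor), the highest of the two numbers. Compound 2 `C=C1C(=O)O[C@H]2C[C@]3(C)O[C@H]3CC/C(C)=C/CC/C(C)=C/C[C@H]12` gives 2.1 ug/mL in this assay, a lower number than compound 1 by a margin beyond the scatter. Going by the values given here, no pair here differs in a single place, so no measured step is available; compound 2 and compound 1 share the core but differ in several places at once, and their two values show only that the less substituted compound 2 returns the lower number.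

The step taken next runs from compound 1 to compound 3 `C=C1C(=O)O[C@H]2C/C(C)=C/CC/C(C)=C/CC[C@@](C)(O)[C@@H](OC(C)=O)C[C@H]12`. The change is hydrogen in place of acetoxy on a saturated ring carbon.

Among the compounds with values here, with no single-place step in hand, the size of the move from compound 1 to compound 3 is uncertain. The two values available hint that a lower number may follow loss of a substituent, so a modest decrease in this assay, at or near the edge of the scatter, is expected: a 1.7-fold lower number from compound 1 to compound 3 (0.24 log units; within the scatter). Compound 3 is estimated at 7 ug/mL, with a range from 2.5 ug/mL to 20 ug/mL.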

Compound 3, half-maximal inhibitory concentration: > 30 ug/mL
Compound 3 was reported as a limit; the forecaster's own chance of this, stated with the estimate: 5%; at least 4.2-fold (0.63 log units) between middle value and limit.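

In this assay the entry for compound 3 is a limit and not a number: the limit of > 30 ug/mL in this assay, at which 1 of the 3 values shown sits. Hydrogen in place of acetoxy on this saturated ring carbon gives an at least 2.4-fold higher number from compound 1 to compound 3 (0.39 log units; beyond the scatter), the first step in the series that changes one place alone, and it ties the acetoxy group here to the lower number of the two compounds. Loss of this substituent therefore does not by itself bring a lower number in this assay, and since the step rests on a limit, its size has a lower bound but no known upper end.

Going by these compounds, whether the effect of this position belongs to the acetoxy group in particular or would also appear with another group on the same ring carbon, such as an amine, a methoxy group or a longer ester like propionyloxy, remains open. On these data alone, the part played by the second acetoxy group, which compound 3 keeps, also remains open.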